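Two thiazolidinedione benzylidene pairs and a predicted chloro analogue

The source may hold more compounds than are shown below. What is called first, only, known or untested is meant among the compounds shown, and "the series" means these compounds.

Compound 1, `Nc1ccc(/C=C2\SC(=O)N(Cc3ccc(C(F)(F)F)cc3)C2=O)cc1`: 6000 nM
Compound 2, `Nc1ccc(/C=C2\SC(=O)N(Cc3ccc(Cl)cc3)C2=O)cc1`: 37000 nM
Compound 3, `Nc1cccc(/C=C2\SC(=O)N(Cc3ccc(C(F)(F)F)cc3)C2=O)c1`: reported only as a limit

Three compounds were tested in a functional assay on L1210 cells (Mus musculus) for cytotoxicity, read by cell counting, with a stated time of 2 days; a higher number here means a weaker inhibitor, a lower number a stronger inhibitor. Compound 1 gives 6000 nM. Compound 2 differs from compound 1 by chloro in place of trifluoromethyl on an aromatic carbon, and this change gave a 6.2-fold higher number from compound 1 to compound 2 (0.79 log units; beyond the scatter). Compound 3 differs from compound 1 in its core, namely (3-aminophenyl in place of 4-aminophenyl on a double-bonded chain carbon bound to a double-bonded ring carbon); for compound 3 the measurement reached only a limit, > 250000 nM, so its value is known just as a bound, (the limit of > 250000 nM in this assay, at which 1 of the 3 values shown sits), and the step of an at least 41-fold higher number from compound 1 to compound 3 (1.61 log units; beyond the scatter) is likewise only a bound.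

Compound 4, `Nc1cccc(/C=C2\SC(=O)N(Cc3ccc(Cl)cc3)C2=O)c1`, has not yet been measured. It differs from compound 3 by chloro in place of trifluoromethyl on an aromatic carbon, the same change as that from compound 1 to compound 2. Given that compound 3 is already at the limit and that the step of a 6.2-fold higher number from compound 1 to compound 2 (0.79 log units; beyond the scatter) weakened the compound, the change from compound 3 to compound 4 is expected to weaken it further, a step that the limit leaves unreadable from compound 3 to compound 4. Compound 4 is therefore expected to give about 1500000 nM, most likely again reported only as a limit, and is estimated to lie between 250000 nM and 8000000 nM.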

Compound 4, half-maximal inhibitory concentration: 218000 nM
Beside the measured number, compound 4's estimate is 6.9-fold (0.84 log units) above it; the measured number lies below the stated range.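

In this assay, chloro in place of trifluoromethyl gave an at least 1.1-fold lower number from compound 3 to compound 4 (0.05 log units; that floor lies within the scatter), which does not repeat the step seen on the core of compound 1: the same change on two cores in this assay, a 6.2-fold higher number (0.79 log units; beyond the scatter) from compound 1 to compound 2 and an at least 1.1-fold lower number (0.05 log units; that floor lies within the scatter) from compound 3 to compound 4, at least 7.0-fold (0.84 log units) apart, beyond the scatter of two such steps. Read the other way, 3-aminophenyl in place of 4-aminophenyl gave a 5.9-fold higher number from compound 2 to compound 4 (0.77 log units; beyond the scatter), a smaller step than in the trifluoromethyl pair: the same change on two cores in this assay, an at least 41-fold higher number (1.61 log units; beyond the scatter) from compound 1 to compound 3 and a 5.9-fold higher number (0.77 log units; beyond the scatter) from compound 2 to compound 4, at least 7.0-fold (0.84 log units) apart, beyond the scatter of two such steps. For compound 3 there is only a limit, so these pairs show that neither change carried over unaltered, but they do not give the true size of either gap, and two pairs set no rule for the wider series: the limit of > 250000 nM in this assay, at which 1 of the 4 values shown sits.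

The compounds shown leave open whether a bromo, methoxy or nitrile group in the place of chloro and trifluoromethyl would behave the same way on both cores. They also leave open how a hydroxyl or an acetamide in place of the amino group would read in this assay.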